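Fluorine on the Tail Ring of a Leukotriene Antagonist

This account rests on a few compounds, and the source may have more. Where it says the series, first, only, none or still open, it means among the compounds named here.

Three compounds share one core and differ only in the ring at the end of a four-carbon chain hung from an aromatic oxygen. Compound 1 `Cc1c(CCCC(=O)O)c2cccc(/C=C/c3ccc(OCCCCc4ccccc4)cc3)c2n1CC(=O)O` carries a plain phenyl there and gives 4.1 nM in a functional assay on CHO-K1 cells for antagonist activity at cysteinyl leukotriene receptor 1 (Homo sapiens), read by fluorescence and calcium flux, with stated times of 30 min and 1 h; on this read-out higher numbers stand for weaker inhibition and lower numbers for stronger inhibition. Compound 2 `Cc1c(CCCC(=O)O)c2cccc(/C=C/c3ccc(OCCCCc4c(F)cc(F)c(F)c4F)cc3)c2n1CC(=O)O` carries a 2,3,4,6-tetrafluorophenyl and gives 1.6 nM. Compound 3 `Cc1c(F)cccc1CCCCOc1ccc(/C=C/c2cccc3c(CCCC(=O)O)c(C)n(CC(=O)O)c23)cc1` carries a 3-fluoro-2-methylphenyl and gives 1.1 nM, the lowest of the three numbers, though its gap to compound 2 stays within the scatter, so the two cannot be ranked.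

Compound 4 `Cc1c(CCCC(=O)O)c2cccc(/C=C/c3ccc(OCCCCc4c(F)ccc(F)c4F)cc3)c2n1CC(=O)O` is the next step: 2,3,6-trifluorophenyl in place of 3-fluoro-2-methylphenyl on a saturated chain carbon, four bonds along the chain from an oxygen on an aromatic ring.

The relevant measured steps are a 2.6-fold lower number from compound 1 to compound 2 (0.41 log units; beyond the scatter) and a 3.7-fold lower number from compound 1 to compound 3 (0.57 log units; beyond the scatter), both modest gains over plain phenyl, and a 1.5-fold lower number from compound 2 to compound 3 (0.16 log units; within the scatter), which lies within the scatter. A trifluorophenyl sits between the tetrafluorophenyl of compound 2 and the fluoro-methyl ring of compound 3 in kind, and both of those give nearly the same number, so for compound 4 the step of a 1.4-fold higher number from compound 3 to compound 4 (0.13 log units; within the scatter) is expected to stay within the scatter, if anything a slight rise. Compound 4 is therefore estimated at 1.5 nM, with a likely range from 0.7 nM to 3.5 nM.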

Compound 4, half-maximal inhibitory concentration in the cysteinyl leukotriene receptor 1 assay: 2.4 nM
Beside the measured number, compound 4's estimate is 1.6-fold (0.20 log units) below it; low and high end bracket the measured number.
By their numbers in the cysteinyl leukotriene receptor 1 assay, from the lowest: compounds 3, 2, 4 and 1 (each within the scatter of the next, the first and the last beyond it).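

In the cysteinyl leukotriene receptor 1 assay there is a 2.2-fold higher number from compound 3 to compound 4 (0.34 log units; beyond the scatter), the first gap between two substituted rings at this position that can be read as real, so the 3-fluoro-2-methylphenyl and the 2,3,6-trifluorophenyl are not interchangeable here. Also in the cysteinyl leukotriene receptor 1 assay, hydrogen in place of fluoro on an aromatic carbon gives a 1.5-fold higher number from compound 2 to compound 4 (0.18 log units; within the scatter), and the step from plain phenyl gives a 1.7-fold lower number from compound 1 to compound 4 (0.23 log units; within the scatter); compound 4 therefore cannot be told apart from either compound 2 or compound 1, although those two can be told apart from each other. In a physicochemical assay for permeability, using PAMPA, with a stated time of 4 h, at pH 6.2, tested at 50 uM (on this read-out higher numbers stand for higher permeability and lower numbers for lower permeability), compound 3 gives 4 10^-6 cm/s and compound 4 gives 4.4 10^-6 cm/s, with a 1.1-fold higher number from compound 3 to compound 4 (0.04 log units; within the scatter), so the ring change that separates these two compounds on the receptor read-out does not separate them on this one.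

Nothing available explains any of these gaps. It remains open how a chloro or methoxy group on this ring, or a longer chain leading to it, would compare with the rings shown.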